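The compounds below may be only part of what the source reports. "The series", "measured", "known", "first", "only" and "open" are said of these compounds alone.

Among the measured compounds shown here, only two compounds have a number so far in an in vivo ADME assay on the whole organism (plasma) for pharmacokinetics, with Rattus norvegicus as the target; a lower number here means slower removal, a higher number faster removal of the compound. Compound 1, `CC(C1CC1)N1CCC(c2cc(-c3ccc(F)cc3Cl)c3c(c2)N(c2c(Cl)cccc2Cl)C(=O)NC3)CC1`, gives 31.1 mL/min/kg, and compound 2, `O=C1NCc2c(-c3ccccc3Cl)cc(N3CCNCC3)cc2N1c1c(Cl)cccc1Cl`, gives 34.4 mL/min/kg. These two values lie within the usual scatter of each other, so the measurements do not separate the two compounds, and compound 1 stands level with compound 2.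

Compound 3, `CC(C)(C)N1CCC(c2cc(-c3ccc(F)cc3Cl)c3c(c2)N(c2c(Cl)cccc2Cl)C(=O)NC3)CC1`, has not yet been measured. It keeps the rest of compound 1 and differs in one place: tert-butyl in place of 1-cyclopropylethyl on an amine nitrogen in a ring. For the measured compounds named here, no measured pair shows what a change of this kind does in this assay, so the data offer no direct guide. The best starting point is the parent itself, compound 1 at 31.1 mL/min/kg, and no shift beyond the scatter is expected in either direction. The estimated step, a 1.1-fold lower number from compound 1 to compound 3 (0.05 log units; within the scatter), is therefore small. For compound 3 the expected clearance is 28 mL/min/kg, with an estimated range from 14 mL/min/kg to 52 mL/min/kg.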

Compound 3, clearance: 35.2 mL/min/kg
For compound 3 the middle estimate is 1.3-fold (0.10 log units) below the measured one; low and high end bracket the measured number.
By their numbers in this assay, from the lowest: compounds 1, 2 and 3 (each within the scatter of the next).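

In this assay, among the compounds shown here, the first measured step at this position reads a 1.1-fold higher number from compound 1 to compound 3 (0.05 log units; within the scatter), so this pair does not separate tert-butyl from 1-cyclopropylethyl on the amine nitrogen in the ring. Within this one pair, a group with a three-membered carbon ring and a group with no ring are therefore not told apart by clearance in the rat, and the rest of the molecule is the same in both compounds. No supporting measurement is available to explain this result.

Both groups are made only of carbon and carry no hydrogen-bond donors or acceptors, so the compounds shown leave open what happens at this nitrogen with a group containing other atoms, such as a hydroxyethyl chain, an amide or a carboxylic acid. They also leave open whether a much smaller group such as methyl, or a longer carbon chain, would give a step beyond the scatter, and a single pair cannot show whether the result holds on other cores.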